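Thiophene sulfonyl piperazines: cytotoxicity limits and one new analogue

A few compounds are considered here, and "the series" means these few. Any claim that something is new, unique, unknown or untested is made for them only; others in the source may bear on it.

Compound 1 `O=C(Nc1cccc([N+](=O)[O-])c1)N1CCN(S(=O)(=O)c2sccc2-c2ccccc2Oc2ccc(O)c(O)c2)CC1` sits at the limit > 20000 nM in an ADME assay on HEK-293T cells (Homo sapiens) for cytotoxicity, read by CCK-8 assay, with a stated time of 48 h; on this read-out higher numbers stand for weaker inhibition and lower numbers for stronger inhibition. Compound 2 `COc1ccc(Oc2ccccc2-c2ccsc2S(=O)(=O)N2CCN(C(=S)Nc3ccc(Cl)cc3)CC2)cc1OC` is likewise reported only as the limit > 20000 nM in this assay. Compound 3 `O=C(Nc1ccc([N+](=O)[O-])cc1)N1CCN(S(=O)(=O)c2sccc2-c2ccccc2Oc2ccc(O)c(O)c2)CC1` also reaches only the limit > 20000 nM in this assay.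

Compound 3 therefore stands at a limit rather than a number, as do both other compounds, since (the limit of > 20000 nM in this assay, at which 3 of the 3 values shown sit). For the measured compounds named here, the one step that can be compared, a step that the two limits leave unreadable from compound 1 to compound 3, is unreadable for the same reason.

Compound 4 `O=S(=O)(c1sccc1-c1ccccc1Oc1ccc(O)c(O)c1)N1CCN(C(=S)Nc2ccc(Cl)cc2)CC1` differs from compound 3 in this way: a group of 10 heavy atoms (7 carbon, 1 nitrogen, 1 sulfur, 1 chlorine; one six-membered aromatic ring of carbon only) in place of a group of 12 heavy atoms (7 carbon, 2 nitrogen, 3 oxygen; one six-membered aromatic ring of carbon only), on an amine nitrogen in a ring. Going by the values given here, compound 2 already carries the entering group on its shared core and is reported only as a limit, so no measured step gives a readable size in this assay for this change.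

The expectation for compound 4 is accordingly that it, too, shows weak inhibition, with an estimated value of 30000 nM (range 15000 nM to 100000 nM). The expected step that the limit leaves unreadable from compound 3 to compound 4 is estimated to lie within the scatter.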

Compound 4, half-maximal inhibitory concentration: > 50000 nM
Compound 4: only a limit was reported; the forecaster's own chance of this, stated with the estimate: 85%; middle value at least 1.6-fold (0.22 log units) from the limit.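

Compound 4 is reported only as a limit, > 50000 nM, in this assay. Its steps from compound 1, compound 2 and compound 3 cannot be read, since those compounds also stand at a limit: the limit of > 20000 nM in this assay, at which 3 of the 4 values shown sit.

The compounds shown leave open what actual value any of them has in this assay, and whether any of these group changes alters it.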